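From 5-nitrofuran-2-yl to 5-nitrothiophen-2-yl on compound 2

The source may hold more compounds than are shown below. What is called first, only, known or untested is meant among the compounds shown, and "the series" means these compounds.

In an ADME assay on Vero cells (Chlorocebus sabaeus) for inhibition, read by sulforhodamine B assay, with a stated time of 48 h (on this read-out higher numbers stand for weaker inhibition of growth and lower numbers for stronger inhibition of growth), compound 1 `O=C(NNC(=O)c1ccc2[nH]c(-c3ccc([N+](=O)[O-])o3)nc2c1)c1ccccc1` gives 31.3 ug/mL and compound 2 `COc1cccc(C(=O)NNC(=O)c2ccc3[nH]c(-c4ccc([N+](=O)[O-])o4)nc3c2)c1` gives 31.3 ug/mL, so compound 2 stands level with compound 1 at the digits shown. Compound 3 `O=C(NNC(=O)c1ccc2[nH]c(-c3ccc([N+](=O)[O-])o3)nc2c1)c1cccc(Oc2ccccc2)c1` gives > 7.8 ug/mL, which is a limit and not a number.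

The next step leads to compound 4 `COc1cccc(C(=O)NNC(=O)c2ccc3[nH]c(-c4ccc([N+](=O)[O-])s4)nc3c2)c1`, with 5-nitrothiophen-2-yl in place of 5-nitrofuran-2-yl on an aromatic carbon, between two ring nitrogen atoms: 5-nitrothiophen-2-yl in place of 5-nitrofuran-2-yl on an aromatic carbon.

For the measured compounds named here, no measured step makes this exchange. All three compounds carry 5-nitrofuran-2-yl, and their steps change a different place on the molecule. Going by the values given here, the one readable step shows no change at the digits printed from compound 1 to compound 2 (within the scatter). The other two give no size, as shown by a step that the limit leaves unreadable from compound 1 to compound 3 and a step that the limit leaves unreadable from compound 2 to compound 3. The data therefore set no size or direction for the exchange, and no step beyond the scatter is expected in this assay. The working anchor is compound 2 at 31.3 ug/mL, with a wide range because the series offers only this one direct reference.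

The expected step is a 1.0-fold lower number from compound 2 to compound 4 (0.00 log units; within the scatter). For compound 4 the estimated value is 31 ug/mL. The expected range for compound 4 runs from 12 ug/mL to 70 ug/mL.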

Compound 4, concentration for 50% growth inhibition: > 250 ug/mL
Compound 4: a limit, no number (the forecaster's own chance of this, stated with the estimate: 20%); middle value at least 8.0-fold (0.90 log units) away from the limit.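

In this assay, for the compounds shown here, 5-nitrothiophen-2-yl in place of 5-nitrofuran-2-yl on an aromatic carbon, between two ring nitrogen atoms, gives an at least 7.9-fold higher number from compound 2 to compound 4 (0.90 log units; beyond the scatter), the only readable step that lies beyond the scatter. This position therefore responds to a change of a single ring atom, with the same count of heavy atoms in the two groups, whereas the methoxy exchange at a different place on the molecule shows no change at the digits printed from compound 1 to compound 2 (within the scatter). The value of compound 4 is a limit and not a number: the limit of > 250 ug/mL in this assay, at which 1 of the 4 values shown sits.

Going by these compounds alone, the steps from compound 1 and compound 2 to compound 3 cannot be read, and the thiophene exchange rests on the single pair of compound 2 and compound 4, so its size with the substituents of compound 1 or compound 3 stays open. Also open, from the compounds shown here alone, is how the same position responds to other groups, such as 4-nitrophenyl or a furan-2-yl ring without the nitro group, which would show whether the nitro group or the ring carries the difference in this assay.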